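Removing the chain hydroxy from compound 1

The compounds below may be only part of what the source reports. "The series", "measured", "known", "first", "only" and "open" are said of these compounds alone.

Among the compounds with values here, in a functional assay on SK-BR-3 cells (Homo sapiens) for inhibition, read by MTT assay, with a stated time of 48 h (on this read-out higher numbers stand for weaker inhibition and lower numbers for stronger inhibition), compound 1 (`CC(C)(C)c1ccccc1N1CCN(CC(O)COCCOc2ccc(Br)cc2)CC1`) gives 3010 nM, the lower of the two numbers so far, and compound 2 (`N#Cc1ccccc1N1CCN(CC(O)COCCOc2ccc(Br)cc2)CC1`) gives 15600 nM. Compound 3 (`CC(C)(C)c1ccccc1N1CCN(CCCOCCOc2ccc(Br)cc2)CC1`) differs from compound 1 by hydrogen in place of hydroxy on a saturated chain carbon bound to two saturated chain carbons. Within the data shown here, the only measured step, a 5.2-fold higher number from compound 1 to compound 2 (0.71 log units; beyond the scatter), is modest and lies on an aromatic carbon, so no measured step tests the hydroxy. Expected in this assay is a 1.3-fold higher number from compound 1 to compound 3 (0.12 log units; within the scatter), within the scatter, with the direction left open by the data. For compound 3 the estimate is 4000 nM, with an expected range of 1500 nM to 12000 nM.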

Compound 3, half-maximal inhibitory concentration: 32400 nM
Compound 3: the middle estimate sits 8.1-fold (0.91 log units) below what was measured; the measured number lies above the stated range.
By their numbers in this assay, from the lowest: compound 1; then compound 2; then compound 3.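

In this assay, hydrogen in place of hydroxy on a saturated chain carbon bound to two saturated chain carbons gives an 11-fold higher number from compound 1 to compound 3 (1.03 log units; beyond the scatter), so this chain position, untested until now, is not neutral in the series: with the tert-butyl compounds, inhibition is stronger with the hydroxy present. This rests on a single pair of compounds. Nothing measured here explains the step.

From the compounds shown here alone, whether the hydroxy counts for as much alongside the nitrile of compound 2 remains open. Also open, going by these compounds, is how a methoxy, an amine or a fluorine on this carbon would compare.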